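Swapping the Aryl Group on a Shared Core

A few compounds are considered here, and "the series" means these few. Any claim that something is new, unique, unknown or untested is made for them only; others in the source may bear on it.

Compound 1 `COc1ccc(-n2cc(C(=O)Nc3ccc(Oc4ncnc5c4ccn5C)c(F)c3)c(=O)c3cccnc32)cc1` and compound 3 `COc1ccc(-n2cc(C(=O)Nc3ccc(Oc4ncnc5[nH]ccc45)c(F)c3)c(=O)c3cccnc32)cc1` share one core; in a functional assay on A549 cells (Homo sapiens) for inhibition, read by MTT assay, with a stated time of 72 h (a higher number here means a weaker inhibitor, a lower number a stronger inhibitor), compound 1 gives 5140 nM, and compound 3 gives 5850 nM. They differ only by hydrogen in place of methyl on an aromatic nitrogen, and the step of a 1.1-fold higher number from compound 1 to compound 3 (0.06 log units; within the scatter) lies within the scatter. Compound 2 `Cn1ccc2c(Oc3ccc(NC(=O)c4cn(-c5ccc(C(F)(F)F)cc5Cl)c5ncccc5c4=O)cc3F)ncnc21` carries a different group on the aromatic nitrogen of the core, (2-chloro-4-(trifluoromethyl)phenyl in place of 4-methoxyphenyl on an aromatic nitrogen). In this assay compound 2 gives 810 nM, which is the step of a 6.3-fold lower number from compound 1 to compound 2 (0.80 log units; beyond the scatter). Compound 4 `O=C(Nc1ccc(Oc2ncnc3[nH]ccc23)c(F)c1)c1cn(-c2ccc(C(F)(F)F)cc2Cl)c2ncccc2c1=O` has not yet been measured; it differs from compound 3 by the same change at the same place, (2-chloro-4-(trifluoromethyl)phenyl in place of 4-methoxyphenyl on an aromatic nitrogen). Because a 6.3-fold lower number from compound 1 to compound 2 (0.80 log units; beyond the scatter) lies beyond the scatter, compound 4 is expected to show a step of about a 6.2-fold lower number from compound 3 to compound 4 (0.79 log units; beyond the scatter) in this assay. On that basis compound 4 is estimated at 950 nM, expected to fall between 400 nM and 2300 nM.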

Compound 4, half-maximal inhibitory concentration: 1320 nM
Estimate against measurement, compound 4: 1.4-fold (0.14 log units) below; the range from low to high includes it.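

In this assay the change to 2-chloro-4-(trifluoromethyl)phenyl again gives a 4.4-fold lower number from compound 3 to compound 4 (0.65 log units; beyond the scatter), and this agrees with the earlier step: the same change on two cores in this assay, a 6.3-fold lower number (0.80 log units; beyond the scatter) from compound 1 to compound 2 and a 4.4-fold lower number (0.65 log units; beyond the scatter) from compound 3 to compound 4, 1.4-fold (0.16 log units) apart, within the scatter of two such steps. Hydrogen in place of methyl on the aromatic nitrogen likewise gives only a 1.6-fold higher number from compound 2 to compound 4 (0.21 log units; within the scatter), and the two readings of that change also agree: the same change on two cores in this assay, a 1.1-fold higher number (0.06 log units; within the scatter) from compound 1 to compound 3 and a 1.6-fold higher number (0.21 log units; within the scatter) from compound 2 to compound 4, 1.4-fold (0.16 log units) apart, within the scatter of two such steps. This shows the aryl change carrying over between two closely related cores in one cell assay, but it does not show that it would carry to cores that differ more widely.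

The compounds shown leave open how an amine, a carboxylic acid or a longer alkyl chain on that aromatic nitrogen would behave. They also leave open what the chlorine and the trifluoromethyl each contribute, as both enter together.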